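The compounds below may be only part of what the source reports. "The series", "measured", "known", "first", "only" and "open" are said of these compounds alone.

Compound 1, `Cc1cc(-c2cnn3c(NCC4CCOCC4)nc(NC4CCOCC4)nc23)ccc1C(=O)NC1CC1`, in a functional assay on MDA-MB-231 cells (Homo sapiens) for antiproliferative activity (on this read-out lower numbers stand for stronger inhibition of growth and higher numbers for weaker inhibition of growth), gives 540 nM.
Compound 2, `O=C(NC1CC1)c1ccc(-c2cnn3c(NCC4CCOCC4)nc(NC4CCCC4)nc23)cc1`, gives 690 nM.
Compound 3, `Cc1cc(-c2cnn3c(NCC4CCOCC4)nc(Nc4ccccc4)nc23)ccc1C(=O)NC1CC1`, gives 1200 nM.

Going by the values given here, compound 3 sits at the high end of these three numbers, although compound 2 lies within the usual scatter of it; only compound 1 differs beyond the scatter, and that is the single one-place step measured here, a 2.2-fold higher number from compound 1 to compound 3 (0.35 log units; beyond the scatter). Compound 4, `CC(=O)Nc1cccc(Oc2nc(NCC3CCOCC3)n3ncc(-c4ccc(C(=O)NC5CC5)c(C)c4)c3n2)c1`, differs from compound 3 by 3-acetamidophenoxy in place of anilino on an aromatic carbon. Among the compounds with values here, no measured step involves this kind of exchange, and the step from compound 1 to compound 3 concerns a different group, so it gives no direct guidance. With nothing pointing either way, the expected step of a 1.2-fold lower number from compound 3 to compound 4 (0.08 log units; within the scatter) is small. Compound 4 is estimated at 1000 nM, with a range from 300 nM to 3500 nM.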

Compound 4, concentration for 50% growth inhibition: 1600 nM
Compound 4: middle estimate off by 1.6-fold (0.20 log units), on the low side, and the stated range covers the measured number.
By their numbers in this assay, from the lowest: compounds 1, 2, 3 and 4 (each within the scatter of the next, the first and the last beyond it).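

Swapping anilino for the larger 3-acetamidophenoxy on this aromatic carbon gives a 1.3-fold higher number from compound 3 to compound 4 (0.12 log units; within the scatter) and so no clear change, which means that the oxygen link and added acetamido group together shift growth inhibition by no more than repeat measurements would. Against the (oxan-4-yl)amino group the same change gives a 3.0-fold higher number from compound 1 to compound 4 (0.47 log units; beyond the scatter) and is the largest step seen at this position. Nothing available explains these steps.

Going by these compounds, whether the oxygen link or the acetamido group counts for more stays open. So does how plain phenoxy or a small amine such as dimethylamino would behave here.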